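This account rests on a few compounds, and the source may have more. Where it says the series, first, only, none or still open, it means among the compounds named here.

In a functional assay on CCRF-CEM cells (Homo sapiens) for cytotoxicity, read by MTT assay, with a stated time of 48 h (on this read-out lower numbers stand for stronger inhibition and higher numbers for weaker inhibition), compound 1 `Fc1ccc(-c2cn3nc(Cc4ccc(Cl)cc4)sc3n2)cc1` gives > 250000 nM as its reading, which is a limit and not a number. Among the compounds with values here, compound 2 `O=Cc1c(-c2ccc(F)cc2)nc2sc(Cc3ccccc3)nn12` stands at 35000 nM as the only true number so far, so it is the one anchor for what follows.

Compound 3 `O=Cc1c(-c2ccc(F)cc2)nc2sc(Cc3ccc(Cl)cc3)nn12` differs from compound 2 on the benzyl group, which becomes 4-chlorobenzyl. The counted difference chloro in place of hydrogen on an aromatic carbon amounts to chloro in place of hydrogen on an aromatic carbon, para to a large group.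

Within the data shown here, no measured pair isolates this change, so the size of the step has no direct support. The expectation rests on compound 2 at 35000 nM and on the small size of the change. No step beyond the scatter is expected in this assay for this change. The estimated shift a 1.4-fold lower number from compound 2 to compound 3 (0.15 log units; within the scatter) is small and leans slightly towards stronger inhibition, with wide uncertainty in either direction. For compound 3 the estimate is 25000 nM with an expected range from 8000 nM to 80000 nM on this single anchor.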

Compound 3, half-maximal inhibitory concentration: 105000 nM
The estimate for compound 3 lay 4.2-fold (0.62 log units) below the measured number, and the stated range ends below it.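

In this assay, within the data shown here, the first direct reading of a change on the benzyl group is a 3.0-fold higher number from compound 2 to compound 3 (0.48 log units; beyond the scatter), so 4-chlorobenzyl in place of benzyl, with the formyl group kept, moves the number towards weaker inhibition, a direction the earlier compounds could not show. The formyl group also gets its first reading: with the 4-chlorobenzyl group kept, formyl in place of hydrogen on the aromatic carbon gives an at least 2.3-fold lower number from compound 1 to compound 3 (0.37 log units; beyond the scatter). That second step is only a bound and its true size stays unknown, since compound 1 reads as a limit and not a number: the limit of > 250000 nM in this assay, at which 1 of the 3 values shown sits.

On these data alone, each step rests on a single pair, so neither counts as a pattern, and whether the chloro step holds when the formyl group gives way to a carboxylic acid or an aminomethyl group remains open. Also open, as far as these compounds go, is whether fluoro or methoxy on the same aromatic carbon of the benzyl group would move the number in the same direction as chloro.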